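The compounds below may be only part of what the source reports. "The series", "measured", "known", "first", "only" and "open" are said of these compounds alone.

In a functional assay on U2OS cells for antagonist activity at proto-oncogene Wnt-3 (Homo sapiens), read by a luciferase reporter, with a stated time of 18 h (on this read-out higher numbers stand for an effect only at larger amounts of compound and lower numbers for an effect already at smaller amounts), compound 1 `CC(C)(C)OC(=O)N1CCC[C@@H]1C(=O)N1CCC(NS(=O)(=O)c2cc(S(=O)(=O)c3ccccc3)ccc2C(F)(F)F)CC1` gives 210 nM, and compound 2 `CC(C)C(=O)N1CCC[C@H]1C(=O)N1CCC(NS(=O)(=O)c2cc(S(=O)(=O)c3ccccc3)ccc2C(F)(F)F)CC1` gives 90 nM; the step of a 2.3-fold lower number from compound 1 to compound 2 (0.37 log units; beyond the scatter) leaves compound 2 with the lower of the two numbers. Compound 3 `O=C([C@@H]1CCCN1C(=O)N1CCOCC1)N1CCC(NS(=O)(=O)c2cc(S(=O)(=O)c3ccccc3)ccc2C(F)(F)F)CC1` is the next step from compound 2: morpholin-4-yl in place of isopropyl on a carbonyl carbon. Within the data shown here, only the step from compound 1 to compound 2 touches this position, and it was modest; no measured step shows a ring entering here. The number for compound 3 is therefore expected to move little, by a 1.7-fold higher number from compound 2 to compound 3 (0.22 log units; within the scatter) in this assay. Compound 3 is estimated at 150 nM, within 50 nM to 500 nM.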

Compound 3, half-maximal effective concentration: 280 nM
For compound 3 the middle estimate is 1.9-fold (0.27 log units) below the measured one; the measured number falls inside the stated range.
By their numbers in this assay, from the lowest: compound 2; then compounds 1 and 3 (each within the scatter of the next).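

In this assay, the first ring to enter on this carbonyl carbon raises the number, a 3.1-fold higher number from compound 2 to compound 3 (0.49 log units; beyond the scatter), so morpholin-4-yl does not stand in for isopropyl without cost. The step is modest, but it runs opposite to the earlier change at this position, and compound 2 remains the lowest of the three. Nothing measured here explains the shift.

From the compounds shown here alone, whether the rise goes with the ring itself or with its oxygen stays open. A piperidin-1-yl or a dimethylamino group on the same carbonyl carbon would help separate the two.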